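The source may report more compounds than this note shows. Statements on the series, on what has been measured and on what is new or still open speak of the compounds shown alone.

Measured: compound 2 `Cc1nc(-c2ccccc2)c(C(=O)N2CCN(c3cccc(C(F)(F)F)c3)CC2)o1`, 153 nM; compound 1 `COc1ccc(-c2nc(C)oc2C(=O)N2CCN(c3cccc(Cl)c3)CC2)cc1`, "not active" (no number reported); compound 3 `CCCc1nc(-c2ccc(OC)c(OC)c2)c(C(=O)N2CCN(c3cccc(Cl)c3)CC2)o1`, "not active" (no number reported).

Among the measured compounds shown here, in a functional assay on HL-60 cells (Homo sapiens) for inhibition, read by MTT assay, with a stated time of 72 h (a lower number here means a stronger inhibitor, a higher number a weaker inhibitor), compound 2 gives 153 nM, the only number in the set; compound 1 and compound 3, which differ from compound 2 in more than one place, return no number. Compound 4 `Cc1nc(-c2ccccc2)c(C(=O)N2CCN(c3ccc(F)cc3)CC2)o1` is not yet measured. Change from compound 2: 4-fluorophenyl in place of 3-(trifluoromethyl)phenyl on an amine nitrogen in a ring. For the measured compounds named here, no step between measured compounds covers this change, so the size is judged from the set alone: the one number belongs to the 3-(trifluoromethyl)phenyl compound, and the two entries with other groups gave none. A loss beyond the scatter is expected, with a fair chance that only a limit is returned. Compound 4 is expected near 700 nM, between 150 nM and 6000 nM. The expected step is a 4.6-fold higher number from compound 2 to compound 4 (0.66 log units; beyond the scatter).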

Compound 4, half-maximal inhibitory concentration: > 1000 nM
Compound 4 ended at the assay's limit; the forecaster's own chance of this, stated with the estimate: 35%; middle value at least 1.4-fold (0.15 log units) away from the limit.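

The first single change read in this assay lies on the amine nitrogen in a ring: 4-fluorophenyl in place of 3-(trifluoromethyl)phenyl gives an at least 6.5-fold higher number from compound 2 to compound 4 (0.81 log units; beyond the scatter). This group therefore counts on the shared core, with the phenyl on the other side unchanged. Compound 4 gives only a limit, > 1000 nM, so the step has a floor and no full size: the limit of > 1000 nM in this assay, at which 1 of the 4 values shown sits.

The compounds shown do not separate the change of substituent from the change of its place on the phenyl ring. On these data alone, how a plain phenyl or a benzyl group on that nitrogen would read also remains open.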